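(Ethoxycarbonyl)amino in Place of (Ethoxycarbonyl)methoxy

The source may report more compounds than this note shows. Statements on the series, on what has been measured and on what is new or still open speak of the compounds shown alone.

Measured so far:
compound 1 `CCCOc1cc(=O)oc2cc(OCc3cccc(F)c3)ccc12` gives 407 nM
compound 2 `CCOC(=O)COc1cc(=O)oc2cc(OCc3cccc(Cl)c3)ccc12` gives 1820 nM

Both compounds were tested in an assay on isolated protein (strain Sprague-Dawley) for inhibition of Amine oxidase [flavin-containing] B (Rattus norvegicus), read by spectrophotometry, with a stated time of 5 min; on this read-out lower numbers stand for stronger inhibition and higher numbers for weaker inhibition. Compound 2 holds the higher of the two numbers; compound 1, its nearest neighbour, sits at a lower value, and the gap between compound 1 and compound 2 lies beyond the usual scatter. The two compounds differ in more than one place, so no single step can be read from them.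

Compound 3 `CCOC(=O)Nc1cc(=O)oc2cc(OCc3cccc(Cl)c3)ccc12` has not yet been measured. It departs from compound 2 by one change: (ethoxycarbonyl)amino in place of (ethoxycarbonyl)methoxy on an aromatic carbon. Going by the values given here, with no step of this kind among the measured compounds, there is nothing to anchor the size or direction of the effect, and an expectation can rest only on the fact that the side chain shrinks by one heavy atom while gaining a hydrogen-bond donor.

The step from compound 2 to compound 3 is expected to be a 1.2-fold lower number from compound 2 to compound 3 (0.08 log units; within the scatter), that is, small and possibly within the scatter. Compound 3 is accordingly estimated at 1500 nM in this assay, with a range from 400 nM to 6000 nM.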

Compound 3, half-maximal inhibitory concentration: 589 nM
Estimate against measurement, compound 3: 2.5-fold (0.41 log units) above; low and high end bracket the measured number.
By their numbers in this assay, from the lowest: compounds 1 and 3 (each within the scatter of the next); then compound 2.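

In this assay, going by these compounds alone, the exchange of (ethoxycarbonyl)methoxy for (ethoxycarbonyl)amino on the aromatic carbon opposite the ring oxygen gives a 3.1-fold lower number from compound 2 to compound 3 (0.49 log units; beyond the scatter), the first step at this position that can be read from a single change. It shows that the number at this position responds to the side chain even when the change is confined to the atoms nearest the shared core: 6 heavy atoms replace 7, nitrogen enters, and 1 hydrogen-bond donor replaces 0, while neither side chain carries a ring or a net charge. No independent measurement is available to explain why the number moves in this direction.

This single step cannot separate the entry of the nitrogen from the loss of a heavy atom, and it rests on one pair of compounds sharing the same substituted benzyloxy group, so it may not carry over to other compounds. It also leaves open how a simple amine, a carboxylic acid or a longer chain would read at this position.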